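Ortho substituent swap on the piperidine aryl group

The source may hold more compounds than are shown below. What is called first, only, known or untested is meant among the compounds shown, and "the series" means these compounds.

Measured so far:
compound 1, `Cc1cccc(NC(=O)CN2CCC(c3nccs3)CC2)c1`, 1 nM
compound 2, `Cc1cccc(NC(=O)CN2CCC(c3ccccc3C)CC2)c1`, 340 nM
compound 3, `Cc1cccc(NC(=O)CN2CCC(c3ccccc3C#N)CC2)c1`, 8 nM

Three compounds share one core and differ only in the group on the saturated ring carbon. In a functional assay on HEK293 cells for agonist activity at D(4) dopamine receptor (Homo sapiens), read by FLIPR (on this read-out lower numbers stand for an effect already at smaller amounts and higher numbers for an effect only at larger amounts of compound), compound 1 gives the lowest number, while compound 3 stands second of the three: it lies an 8.0-fold higher number from compound 1 to compound 3 (0.90 log units; beyond the scatter) and a 43-fold lower number from compound 2 to compound 3 (1.63 log units; beyond the scatter). For the measured compounds named here, the one step that changes only the group on the aromatic carbon, a 43-fold lower number from compound 2 to compound 3 (1.63 log units; beyond the scatter), is large.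

Compound 4, `Cc1cccc(NC(=O)CN2CCC(c3ccccc3F)CC2)c1`, has not been measured. It differs from compound 3 in one place: fluoro in place of cyano on an aromatic carbon. Going by the values given here, no measured step exchanges cyano for fluoro, so only the methyl-to-cyano step gives a bearing. Because that step was a 43-fold lower number from compound 2 to compound 3 (1.63 log units; beyond the scatter), a change away from cyano is expected to push the number up, though fluoro need not behave like methyl. Compound 4 is therefore estimated at 60 nM, between 15 nM and 300 nM, which would mean an expected step of a 7.5-fold higher number from compound 3 to compound 4 (0.88 log units; beyond the scatter).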

Compound 4, half-maximal effective concentration: 1 nM
The estimate for compound 4 lay 60-fold (1.78 log units) above the measured number; measured number outside the range, below it.
By their numbers in this assay, from the lowest: compounds 1 and 4 (each within the scatter of the next); then compound 3; then compound 2.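

Fluoro on this aromatic carbon, ortho to a large group, gives an 8.0-fold lower number from compound 3 to compound 4 (0.90 log units; beyond the scatter) and a 340-fold lower number from compound 2 to compound 4 (2.53 log units; beyond the scatter), so leaving cyano does not by itself raise the number, and the methyl-to-cyano step did not set the direction for other groups here. The order of the three groups at this place is now fluoro, then cyano, then methyl, and it does not follow the heavy-atom count alone, since methyl and fluoro each bring few atoms yet stand furthest apart. The 2-fluorophenyl group also gives no change at the digits printed from compound 1 to compound 4 (within the scatter), so, unlike the 2-methylphenyl and 2-cyanophenyl groups, it cannot be told apart from 1,3-thiazol-2-yl on the saturated ring carbon. Nothing at hand accounts for these differences. On these data alone, it remains open whether a chloro, a methoxy or an amine on the same aromatic carbon would stay with fluoro or move towards methyl.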